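Methyl on the shared core: a small change, twice

The compounds below may be only part of what the source reports. "The series", "measured", "known", "first", "only" and "open" are said of these compounds alone.

Measured so far, in a functional assay on SW-620 cells (Homo sapiens) for antiproliferative activity, read by MTT assay, with a stated time of 72 h; a lower number here means a stronger inhibitor, a higher number a weaker inhibitor:
- compound 1, `COCn1c(CC(COCc2ccccc2)COCc2ccccc2)cc(=O)[nH]c1=O`, gives > 100000 nM, a limit of the assay rather than a number.
- compound 2, `COCn1c(CC(COCc2ccccc2)COCc2ccccc2)c(C)c(=O)[nH]c1=O`, gives 72100 nM.
- compound 3, `C[Si](C)(C)CCOCn1c(CC(O)CO)cc(=O)[nH]c1=O`, gives > 100000 nM, again a limit of the assay.

Compound 1 and compound 2 differ in one place: methyl in place of hydrogen on an aromatic carbon. The step is an at least 1.3-fold lower number from compound 1 to compound 2 (0.14 log units; that floor lies within the scatter); it is only a floor because of the limit of > 100000 nM in this assay, at which 2 of the 3 values shown sit, so its true size is not known.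

Compound 3 carries a different core from compound 1, and the difference between the two cores is not broken down here. Compound 4, `Cc1c(CC(O)CO)n(COCC[Si](C)(C)C)c(=O)[nH]c1=O`, has not yet been measured in this assay. It differs from compound 3 by methyl in place of hydrogen on an aromatic carbon, the same kind of change as that from compound 1 to compound 2, though the surroundings differ: in compound 4 the entering methyl sits ortho to a 2,3-dihydroxypropyl group and meta to a group of 8 heavy atoms, whereas in compound 2 it sits ortho to a large group and meta to a methoxymethyl group.

Since compound 3 stands at a limit, the starting point for compound 4 is itself uncertain. The expected step is a number no higher from compound 3 to compound 4 (the limit leaves the size open), resting on the modest and floor-only gain seen from compound 1 to compound 2 in an at least 1.3-fold lower number from compound 1 to compound 2 (0.14 log units; that floor lies within the scatter). Compound 4 is therefore estimated at 100000 nM, with a range from 40000 nM to 300000 nM, and a real chance that only a limit is reported.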

Compound 4, half-maximal inhibitory concentration: > 100000 nM
Compound 4 was reported as a limit; the forecaster's own chance of this, stated with the estimate: 55%; the middle value lies on the limit itself.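

Compound 3 and compound 4 both stand at a limit of the assay rather than at a number, so no step can be read between them: the limit of > 100000 nM in this assay, at which 3 of the 4 values shown sit.

The compounds shown leave open whether methyl in place of hydrogen on an aromatic carbon changes the result at all on the core of compound 3, and how weak compound 3 and compound 4 truly are.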